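A Sulfonyl Aryl Swap on a Weakly Active Core

The source may hold more compounds than are shown below. What is called first, only, known or untested is meant among the compounds shown, and "the series" means these compounds.

Measured so far:
compound 1 `COc1ccc(-c2[nH]c3cc(OC)cc(OC)c3c(=O)c2I)cc1` — 49400 nM
compound 2 `COc1ccc(-c2cc(=O)c3c(OC)cc(OC)cc3n2S(=O)(=O)c2cccc([N+](=O)[O-])c2)cc1` — > 39600 nM

Of the compounds shown here, two have been measured in a functional assay on KOPN-8 cells (Homo sapiens) for antiproliferative activity, with a stated time of 72 h; on this read-out higher numbers stand for an effect only at larger amounts of compound and lower numbers for an effect already at smaller amounts. Compound 1 gives 49400 nM. For compound 2 only a limit is recorded, > 39600 nM, which is the limit of > 39600 nM in this assay, at which 1 of the 2 values shown sits. Compound 3 `COc1ccc(-c2cc(=O)c3c(OC)cc(OC)cc3n2S(=O)(=O)c2ccc(Cl)cc2)cc1` differs from compound 2 by 4-chlorophenyl in place of 3-nitrophenyl on a sulfonyl sulfur. Within the data shown here, no measured step bears on this change, so no shift beyond the scatter in this assay is expected in either direction. The step implied by the estimate, a step that the limit leaves unreadable from compound 2 to compound 3, is expected to be small. Compound 3 is estimated at 40000 nM, within 10000 nM to 150000 nM, with a fair chance that only a limit is reported again.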

Compound 3, half-maximal effective concentration: > 34400 nM
Compound 3 was reported as a limit (the forecaster's own chance of this, stated with the estimate: 60%); the middle value lies beyond the limit too.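

Compound 2 and compound 3 both stand only as limits in this assay, and the step between them cannot be read. Going by these compounds, whether 4-chlorophenyl in place of 3-nitrophenyl on the sulfonyl sulfur changes activity at all remains open.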